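Working notes: removing a fluoro from compound 2

The source may hold more compounds than are shown below. What is called first, only, known or untested is meant among the compounds shown, and "the series" means these compounds.

Two compounds of the series have been run in an ADME assay on Huh-7 cells (Homo sapiens) for cytotoxicity, read by MTT assay, with a stated time of 72 h; a lower number here means that less compound is tolerated, a higher number that more compound is tolerated. Compound 1 `COc1cc(OC)c2c(=O)cc(-c3ccc(OCc4cn(-c5ccc(F)cc5Cl)nn4)c(OCc4cn(-c5ccc(F)cc5Cl)nn4)c3)oc2c1` gives > 100 ug/mL, which is a limit of the assay rather than a number. Compound 2 `COc1cc(O)c(C(=O)/C=C/c2ccc(OCc3cn(-c4ccc(F)cc4Cl)nn3)c(OC)c2)c(OC)c1` gives > 100 ug/mL, again a limit of the assay and not a number. Both values sit at the limit of > 100 ug/mL in this assay, at which 2 of the 2 values shown sit, so compound 2 stands at the top of the tested range, with no toxicity recorded up to that point. Within the data shown here, no step between measured compounds can be stated, since no two measured compounds differ in only one place.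

Compound 3 `COc1cc(O)c(C(=O)/C=C/c2ccc(OCc3cn(-c4ccccc4Cl)nn3)c(OC)c2)c(OC)c1` differs from compound 2 by hydrogen in place of fluoro on an aromatic carbon. Among the measured compounds shown here, with both measured values at a limit, there is no basis for a step of any size. The step of a number no higher from compound 2 to compound 3 (the limit leaves the size open) is expected to be none beyond the scatter. Compound 3 is therefore expected to give 100 ug/mL, within 50 ug/mL to 200 ug/mL, in this assay.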

Compound 3, half-maximal cytotoxic concentration: > 100 ug/mL
Compound 3 ended at the assay's limit (the forecaster's own chance of this, stated with the estimate: 80%); the middle value sits exactly at the limit.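

No step from compound 2 to compound 3 can be read in this assay, since both compounds stand at a limit of the assay and not at a number: the limit of > 100 ug/mL in this assay, at which 3 of the 3 values shown sit.

The compounds shown leave open whether the 2-chloro-4-fluorophenyl to 2-chlorophenyl change alters tolerance at all, and at what concentration any of the three becomes cytotoxic.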